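Arylidene exchange on the shared core: compound 3 to compound 4

The source may hold more compounds than are shown below. What is called first, only, known or untested is meant among the compounds shown, and "the series" means these compounds.

Three members of the series carry numbers in a functional assay on MCF7 cells (Homo sapiens) for cytotoxicity, read by CCK-8 assay, with a stated time of 72 h; on this read-out higher numbers stand for weaker inhibition and lower numbers for stronger inhibition. Compound 1 `C=CCn1c(=O)/c(=C\c2cccc(F)c2)[nH]c(=O)/c1=C\c1ccccc1OC` gives 13700 nM, compound 2 `C=CCn1c(=O)/c(=C\c2cccc(Cl)c2Cl)[nH]c(=O)/c1=C\c1ccccc1OC` gives 2100 nM, and compound 3 `C=CCn1c(=O)/c(=C\c2ccccc2OC)[nH]c(=O)/c1=C\c1ccccc1OC` gives 41100 nM. Compound 3 stands highest of the three numbers; the nearer gap is a 3.0-fold higher number from compound 1 to compound 3 (0.48 log units; beyond the scatter) and the wider gap is a 20-fold higher number from compound 2 to compound 3 (1.29 log units; beyond the scatter). Between the two halogen-bearing members the step is a 6.5-fold lower number from compound 1 to compound 2 (0.81 log units; beyond the scatter).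

Compound 4 `C=CCn1c(=O)/c(=C\c2ccc(C)cc2)[nH]c(=O)/c1=C\c1ccccc1OC` is not yet measured in this assay. It differs from compound 3 by 4-methylphenyl in place of 2-methoxyphenyl on a double-bonded chain carbon bound to an aromatic carbon. For the measured compounds named here, no measured step tests this exact exchange, and no member of the series carries 4-methylphenyl. Going by the values given here, the steps that bear on it are the two in which 2-methoxyphenyl enters, a 3.0-fold higher number from compound 1 to compound 3 (0.48 log units; beyond the scatter) and a 20-fold higher number from compound 2 to compound 3 (1.29 log units; beyond the scatter), both running toward higher numbers; read in reverse, leaving 2-methoxyphenyl has gone with lower numbers in both cases. The entering ring here is not one of those halogen-bearing rings, so the step is expected to be modest rather than large. For compound 4 a step of a 2.7-fold lower number from compound 3 to compound 4 (0.44 log units; beyond the scatter) toward a lower number is therefore expected. The estimate for compound 4 in this assay is 15000 nM, with a range from 4000 nM to 45000 nM.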

Compound 4, half-maximal inhibitory concentration: "not active" (no number reported)
Nothing numeric was reported for compound 4; the estimate stays without a comparison.
By their numbers in this assay, from the lowest: compound 2; then compound 1; then compound 3.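

In this assay, for the compounds shown here, compound 4 is reported as "not active" without a number, so no step from compound 3 or any other compound to compound 4 can be read. Nothing shown bears on this result. The compounds shown leave open how 4-methylphenyl compares numerically with 2-methoxyphenyl on the shared core.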